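Pyridin-2-yl for 4-fluorophenyl on compound 1

This account rests on a few compounds, and the source may have more. Where it says the series, first, only, none or still open, it means among the compounds named here.

Measured so far:
- compound 1 (`CCCCc1ccc2[nH]c(-c3ccc(OC)cc3)c(/C=N/NC(=O)c3ccc(F)cc3)c2c1`): 19 nM
- compound 2 (`CCCCc1ccc2[nH]c(-c3ccc(C(F)(F)F)cc3)c(/C=N/NC(=O)c3ccncc3)c2c1`): 94 nM

In a functional assay on MDA-MB-231 cells (Homo sapiens) for antiproliferative activity, with a stated time of 4 days (on this read-out higher numbers stand for weaker inhibition and lower numbers for stronger inhibition), compound 1 (19 nM) holds the lower of the two numbers, and compound 2 (94 nM) lies above it by more than the usual scatter. Going by the values given here, the two differ in more than one place, so no single-change step has been measured yet. Compound 3 (`CCCCc1ccc2[nH]c(-c3ccc(OC)cc3)c(/C=N/NC(=O)c3ccccn3)c2c1`) keeps the core of compound 1 and carries pyridin-2-yl in place of 4-fluorophenyl on a carbonyl carbon. For compound 3 the expected step (a 2.2-fold higher number from compound 1 to compound 3 (0.34 log units; beyond the scatter)) is a modest rise in the number in this assay and not a fall. This expectation rests only on the higher number of compound 2 (94 nM) and is a weak guide. Compound 3 is estimated at 42 nM (range 13 nM to 135 nM).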

Compound 3, half-maximal inhibitory concentration: 34 nM
Beside the measured number, compound 3's estimate is 1.2-fold (0.09 log units) above it; the range from low to high includes it.
By their numbers in this assay, from the lowest: compounds 1 and 3 (each within the scatter of the next); then compound 2.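

In this assay, the position on the carbonyl carbon now has its first single-change comparison, and a 1.8-fold higher number from compound 1 to compound 3 (0.25 log units; within the scatter) marks the exchange of 4-fluorophenyl for pyridin-2-yl. At this position, then, a carbon-only aromatic ring carrying fluorine and an aromatic ring with one hetero atom and one hydrogen-bond acceptor cannot be told apart in this read-out, at least on the core of compound 1. No measured evidence bears on this result.

Compound 2 still differs from compound 1 in more than one place, so its higher number cannot be assigned to any one change. Open is how this position responds to a group outside the aromatic rings shown, such as a morpholine or a carboxylic acid on the carbonyl carbon.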